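The compounds below may be only part of what the source reports. "The series", "measured", "known", "first", "only" and "open" are said of these compounds alone.

In a functional assay on SMMC-7721 cells (Homo sapiens) for cytotoxicity, read by MTT assay, with a stated time of 24 h (on this read-out lower numbers stand for stronger inhibition and higher numbers for weaker inhibition), compound 1 (`CN1C/C(=C\c2cccnc2)C(=O)/C(=C/c2ccccc2F)C1`) gives 5420 nM. Compound 2 (`CN1C/C(=C\c2cccnc2)C(=O)/C(=C/c2cc([N+](=O)[O-])ccc2F)C1`) gives 6170 nM, and the step of a 1.1-fold higher number from compound 1 to compound 2 (0.06 log units; within the scatter) stays within the scatter. Compound 3 (`CN1C/C(=C\c2ccc(C#N)cc2)C(=O)/C(=C/c2cccnc2)C1`) gives 13600 nM, with a modest step of a 2.5-fold higher number from compound 1 to compound 3 (0.40 log units; beyond the scatter). Compound 1 and compound 2 therefore form the low end of these numbers, with compound 3 above them.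

Compound 4 (`O=C1/C(=C/c2cccnc2)CN(S(=O)(=O)c2ccccc2)C/C1=C\c1ccccc1F`) differs from compound 1 in one place, with phenylsulfonyl in place of methyl on an amine nitrogen in a ring. Among the compounds with values here, neither measured step touches that nitrogen, since all three measured compounds carry methyl there, so the data offer no direct precedent. The two steps serve only as a gauge of size: changes elsewhere on the shared core gave a 1.1-fold higher number from compound 1 to compound 2 (0.06 log units; within the scatter) and a 2.5-fold higher number from compound 1 to compound 3 (0.40 log units; beyond the scatter). A step of similar small size is expected in this assay, with no confident direction and possibly none beyond the scatter. The expected step, an estimate only, is a 1.2-fold lower number from compound 1 to compound 4 (0.08 log units; within the scatter). Compound 4 is estimated at 4500 nM, with an expected range from 1500 nM to 13000 nM.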

Compound 4, half-maximal inhibitory concentration: 19100 nM
For compound 4 the middle estimate is 4.2-fold (0.63 log units) below the measured one; measured number above the stated range.
By their numbers in this assay, from the lowest: compounds 1 and 2 (each within the scatter of the next); then compounds 3 and 4 (each within the scatter of the next).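

In this assay, within the data shown here, phenylsulfonyl in place of methyl on the amine nitrogen in the ring gives a 3.5-fold higher number from compound 1 to compound 4 (0.55 log units; beyond the scatter) as a modest step, the first reading at this position, which carries methyl in all the earlier compounds. The number moves toward weaker inhibition, so this nitrogen is not a silent position in this read-out, although that rests on a single pair. No measurement bearing on the cause of this step is available.

Open, as far as these compounds go, is whether the step belongs to the sulfonyl link or to the phenyl ring it carries, as the two enter together here. From the compounds shown here alone, an acetyl group, a benzyl group or a plain hydrogen on the same nitrogen would separate these two parts, and whether the step holds with other groups on the shared core also stays open.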